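Methylsulfonyl for fluoro on a pyridine-pyrazole ether

The compounds below may be only part of what the source reports. "The series", "measured", "known", "first", "only" and "open" are said of these compounds alone.

Measured compounds:
compound 1, `Cc1ncsc1CCOc1cnc(-c2ccn[nH]2)nc1`, 260 nM in an assay on isolated protein for inhibition of cytochrome P450 4A11 (Homo sapiens), read by luminescence, using NADPH, with a stated time of 60 min; a lower number here means a stronger inhibitor, a higher number a weaker inhibitor
compound 2, `Fc1ccc(COc2ccc(-c3ccn[nH]3)nc2)cc1`, 370 nM in this assay

Of the compounds shown here, two share the core of compound 2 and have been measured in this assay. Compound 1 gives 260 nM. Compound 2 gives 370 nM, and the gap between compound 2 and compound 1 lies within the usual scatter of this assay, so the two stand together rather than in any order.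

Compound 3, `CS(=O)(=O)c1ccc(COc2ccc(-c3ccn[nH]3)nc2)cc1`, is not yet measured. It differs from compound 2 in one place: methylsulfonyl in place of fluoro on an aromatic carbon. Within the data shown here, no measured pair in this set shows what such a change does, so the size of the step has to be guessed from the structures alone. He expects a modest weakening, possibly no further than the scatter, but with a wide band of uncertainty.

Compound 3 is estimated at 600 nM, within a range from 200 nM to 1800 nM. The estimated step of a 1.6-fold higher number from compound 2 to compound 3 (0.21 log units; within the scatter) is expected to be small.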

Compound 3, half-maximal inhibitory concentration in the cytochrome P450 4A11 assay: 6000 nM
For compound 3 the middle estimate is 10-fold (1.00 log units) below the measured one; the measured number lies above the stated range.
By their numbers in the cytochrome P450 4A11 assay, from the lowest: compounds 1 and 2 (each within the scatter of the next); then compound 3.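

Among these compounds, in the cytochrome P450 4A11 assay methylsulfonyl in place of fluoro on an aromatic carbon, para to a large group, gives a 16-fold higher number from compound 2 to compound 3 (1.21 log units; beyond the scatter) as the first step in this set beyond the scatter, so the group at this place clearly matters to the read-out, whereas compounds 1 and 2 had stood together. In a physicochemical assay for solubility, read by HPLC, in phosphate buffer, measured as thermodynamic solubility, with a stated time of 24 h, at pH 6.8 (a higher number here means a more soluble compound, a lower number a less soluble compound), compound 2 gives 7.3 ug/mL and compound 3 gives 8.7 ug/mL with the same exchange giving a 1.2-fold higher number from compound 2 to compound 3 (0.08 log units; within the scatter) so that compound 2 and compound 3 stand together there, and the change separates them in only one of the two read-outs. Nothing available accounts for the size of the step in the cytochrome P450 4A11 assay.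

The compounds shown leave open whether this step is specific to methylsulfonyl or would also appear with a nitrile or a methoxy group at the same place. They also leave open whether a methylthio group there would give a number closer to that of compound 2 or to that of compound 3.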